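From cyclopropylmethyl to oxan-4-yl at a cytotoxicity limit

The source may report more compounds than this note shows. Statements on the series, on what has been measured and on what is new or still open speak of the compounds shown alone.

Measured so far in an ADME assay on MT4 cells (Homo sapiens) for cytotoxicity, read by MTT assay, with a stated time of 5 days (a higher number here means that more compound is tolerated, a lower number that less compound is tolerated), are these compounds:
- compound 1 (`CCNc1cc(Oc2c(OC)cc3cc(C#N)ccc3c2OC)nc(Nc2ccc(C#N)cc2)n1`) at > 125000 nM as a limit
- compound 2 (`COc1cc2cc(C#N)ccc2c(OC)c1Oc1cc(NCC2CC2)nc(Nc2ccc(C#N)cc2)n1`) at > 125000 nM as a limit

Compound 2 stands at > 125000 nM and this is a limit, not a number. Compound 3 (`COc1cc2cc(C#N)ccc2c(OC)c1Oc1cc(NC2CCOCC2)nc(Nc2ccc(C#N)cc2)n1`) carries oxan-4-yl in place of cyclopropylmethyl on a nitrogen on an aromatic ring. Among the measured compounds shown here, the one measured step that bears on this is a step that the two limits leave unreadable from compound 1 to compound 2 and it offers no size to carry over. Both measured compounds share the limit of > 125000 nM in this assay, at which 2 of the 2 values shown sit, and so no clear step is expected in this assay in either direction. The expected change is a number no higher from compound 2 to compound 3 (the limit leaves the size open) and no larger. Compound 3 is estimated at 125000 nM with an expected range from 50000 nM to 250000 nM in this measurement.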

Compound 3, half-maximal cytotoxic concentration: > 125000 nM
Compound 3: only a limit was reported; the forecaster's own chance of this, stated with the estimate: 75%; the middle value lies on the limit itself.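

No step can be read among compound 1, compound 2 and compound 3, because all three sit at one limit: the limit of > 125000 nM in this assay, at which 3 of the 3 values shown sit.

The compounds shown leave open where the half-maximal cytotoxic concentration of each lies, and whether exchanging the group on the nitrogen changes it at all.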